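This account rests on a few compounds, and the source may have more. Where it says the series, first, only, none or still open, it means among the compounds named here.

Compounds measured in an ADME assay on Huh-7 cells (Homo sapiens) for cytotoxicity; on this read-out lower numbers stand for higher toxicity in this test and higher numbers for lower toxicity in this test:
compound 1 `CN1CCN(CCCNCc2cn(-c3ccc(C(F)(F)F)cc3)nc2-c2ccc(OC(F)(F)F)cc2)CC1`, 2300 nM
compound 2 `Cc1ccccc1CNc1nn(-c2ccc(F)cc2F)cc1CNCCN1CCN(C)CC1`, > 20000 nM (a limit of this assay)
compound 3 `CN1CCN(CCNCc2cn(-c3ccc(F)cc3F)nc2-c2ccc(Cl)cc2)CC1`, 19000 nM

Compound 1 gives the lowest of the two numbers in this assay; compound 3 is nearest, and the gap to it lies beyond the scatter. For compound 2 this assay returned only a limit. Going by the values given here, the one step measured between compounds, an at least 1.0-fold lower number from compound 2 to compound 3 (0.02 log units; that floor lies within the scatter), concerns a different part of the molecule.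

Compound 4 `CN1CCN(CCCNCc2cn(-c3ccc(C(F)(F)F)cc3)nc2-c2ccc(C(F)(F)F)cc2)CC1` differs from compound 1 by trifluoromethyl in place of trifluoromethoxy on an aromatic carbon. Among the compounds with values here, no measured step in this assay bears on this change, so compound 1 alone is the anchor. Compound 4 is therefore expected to sit near compound 1 in this assay, with a 1.1-fold higher number from compound 1 to compound 4 (0.04 log units; within the scatter) as the expected step. The estimate for compound 4 is 2500 nM, between 900 nM and 7000 nM.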

Compound 4, half-maximal cytotoxic concentration: 2000 nM
For compound 4 the middle estimate is 1.3-fold (0.10 log units) above the measured one, and the stated range covers the measured number.
By their numbers in this assay, from the lowest: compounds 4 and 1 (each within the scatter of the next); then compound 3. At a limit, above all of these: compound 2.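

Among the compounds shown, this is the only step at this position, the aromatic carbon para to a large group. In this assay, trifluoromethyl in place of trifluoromethoxy gives a 1.2-fold lower number from compound 1 to compound 4 (0.06 log units; within the scatter), so this change, which removes the oxygen, leaves the number within the scatter. Nothing measured here accounts for this result. As far as these compounds go, whether this holds for other groups at this position, such as an amine or a carboxylic acid, remains open. So does whether the same change gives a similar step on a core carrying a different group on its other aromatic ring.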